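Dichlorophenyl Sulfone Replaces Methoxyphenyl in a Quinoline Series

This account rests on a few compounds, and the source may have more. Where it says the series, first, only, none or still open, it means among the compounds named here.

Measured compounds:
compound 1 `COc1ccc2ncc(S(=O)(=O)c3ccc(C)c(Cl)c3)c(N3CCC(C)CC3)c2c1` — 85%
compound 2 `COc1ccc(S(=O)(=O)c2cnc3c(F)cccc3c2N2CCC(C)CC2)cc1` — 67%
compound 3 `CC1CCN(c2c(S(=O)(=O)c3ccc(C#N)cc3)cnc3cc(F)ccc23)CC1` — 83%

In an assay on isolated protein for displacement of a labelled ligand from metabotropic glutamate receptor 5 (Homo sapiens), with a stated time of 60 min, tested at 1 uM (a lower number here means less inhibition, a higher number more inhibition at the concentration tested (going by the name of the read-out)), compound 2 gives 67%, the lowest of the three numbers; compound 3 sits higher beyond the scatter, and compound 1 higher still, also beyond the scatter. Compound 4 `CC1CCN(c2c(S(=O)(=O)c3ccc(Cl)c(Cl)c3)cnc3c(F)cccc23)CC1` has not yet been measured in this assay. Its change from compound 2 is 3,4-dichlorophenyl in place of 4-methoxyphenyl on a sulfonyl sulfur. The two compounds carrying a chlorine or a nitrile on that ring, compound 1 and compound 3, both give higher numbers than compound 2, so the step of a number 15 percentage points higher from compound 2 to compound 4 (beyond the scatter) is expected to be an increase beyond the scatter. Compound 4 is therefore estimated to give 82% in this assay, within a range from 70% to 92%.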

Compound 4, a percentage reported as inhibition, at one concentration (the size of the read-out at that concentration, not a potency): 95%
The estimate for compound 4 lay 13 percentage points below the measured number, outside the stated range (above it).
By their numbers in this assay, from the lowest: compound 2; then compounds 3, 1 and 4 (each within the scatter of the next, the first and the last beyond it).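

In this assay, 3,4-dichlorophenyl in place of 4-methoxyphenyl on a sulfonyl sulfur gives a number 28 percentage points higher from compound 2 to compound 4 (beyond the scatter) with the rest of the molecule unchanged. Among the compounds shown here, compounds 1 and 3 each differ from compound 2 in more than one place, so only this pair ties a rise beyond the scatter to the sulfonyl substituent alone. Nothing measured here explains the rise. The compounds shown leave open whether a single chlorine on the phenyl ring would suffice. They also leave open how an amine or a carboxylic acid on that ring would fare.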